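The compounds below may be only part of what the source reports. "The series", "measured", "known", "first", "only" and "open" are said of these compounds alone.

In a functional assay on K562 cells (Homo sapiens) for antiproliferative activity, with a stated time of 72 h (on this read-out higher numbers stand for weaker inhibition and lower numbers for stronger inhibition), compound 1 `OC[C@H]1O[C@@H](n2cnc3c(NCc4cccc(Br)c4)ncnc32)[C@H](O)[C@@H]1O`, which carries bromo on an aromatic carbon, gives 19700 nM. Compound 2 `Cc1cccc(CNc2ncnc3c2ncn3[C@@H]2O[C@H](CO)[C@@H](O)[C@H]2O)c1`, with methyl in that place, reads > 166000 nM, which is a limit and not a number. Compound 3 `OC[C@H]1O[C@@H](n2cnc3c(NCc4cccc(C(F)(F)F)c4)ncnc32)[C@H](O)[C@@H]1O`, with trifluoromethyl there, reads > 166000 nM, which is also only a limit. Compound 3 therefore has no exact value and stands at the limit of > 166000 nM in this assay, at which 2 of the 3 values shown sit.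

Compound 4 `OC[C@H]1O[C@@H](n2cnc3c(NCc4cccc(OC(F)(F)F)c4)ncnc32)[C@H](O)[C@@H]1O` alters just that group: trifluoromethoxy in place of trifluoromethyl on an aromatic carbon. For the measured compounds named here, two measured steps bear on this change: an at least 8.4-fold higher number from compound 1 to compound 2 (0.92 log units; beyond the scatter) and an at least 8.4-fold higher number from compound 1 to compound 3 (0.92 log units; beyond the scatter). Both lie beyond the scatter and show that replacing the bromo of compound 1 weakened inhibition. The step that the two limits leave unreadable from compound 2 to compound 3 cannot be sized. With trifluoromethoxy close in kind to trifluoromethyl, compound 4 is expected to remain weak, and another limit is quite possible.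

The estimated change is an at least 1.6-fold lower number from compound 3 to compound 4 (0.22 log units; that floor lies within the scatter), and it can only be modest.

For compound 4, the estimated value is 100000 nM, within an expected range of 25000 nM to 250000 nM.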

Compound 4, half-maximal inhibitory concentration: > 166000 nM
Compound 4 was reported as a limit; the forecaster's own chance of this, stated with the estimate: 55%; middle value at least 1.6-fold (0.22 log units) from the limit.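

In this assay, compound 4 reads > 166000 nM, which is a limit and not a number. Trifluoromethoxy in place of bromo gives an at least 8.4-fold higher number from compound 1 to compound 4 (0.92 log units; beyond the scatter), so this is a third replacement at this position, after methyl and trifluoromethyl, that leaves the compound with no exact value, and the result now rests on more compounds: the limit of > 166000 nM in this assay, at which 3 of the 4 values shown sit. The steps among compound 2, compound 3 and compound 4 cannot be read, so these three groups cannot be put in any order.

On these data alone, compound 1 is the only one of the four with an exact value, so it remains open whether bromo is unusual here or whether other groups would also give a readable result. Chloro, iodo, an amine or a carboxylic acid at this position could begin to settle that question.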